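The source may hold more compounds than are shown below. What is called first, only, known or untested is meant among the compounds shown, and "the series" means these compounds.

Working notes on the series. For the measured compounds named here, in a functional assay on KG-1 cells (Homo sapiens) for cytotoxicity, read by luminescence and CellTiter-Glo, with a stated time of 3 days (on this read-out lower numbers stand for stronger inhibition and higher numbers for weaker inhibition), compound 1 `N#Cc1ccc(NC(=O)c2ccc(-c3cccnc3)cc2O)cc1` gives 7940 nM, the only true number available so far. Compound 2 `O=C(Nc1ccccc1)c1cc(F)ccc1O` reads > 10000 nM in this assay, and this is a limit of the assay, not a number. Compound 1 therefore stands alone as a numerical anchor, with no second number for comparison.

The next compound to be read is compound 3 `N#Cc1ccc(NC(=O)c2ccc(-c3ccccc3)cc2O)cc1`. It keeps the core of compound 1 but has phenyl in place of pyridin-3-yl on an aromatic carbon, meta to a hydroxy group and para to a large group (phenyl in place of pyridin-3-yl on an aromatic carbon).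

Going by the values given here, no pair of measured compounds differs in a single place, so the series offers no measured step to size this change. With compound 1 at 7940 nM as the sole basis, no shift beyond the usual scatter is expected in this assay, and no direction is favoured with any confidence. The expected step of a 1.2-fold lower number from compound 1 to compound 3 (0.09 log units; within the scatter) is accordingly small. For compound 3 the estimated value is 6500 nM, with an expected range of 2500 nM to 10000 nM.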

Compound 3, half-maximal inhibitory concentration: 410 nM
Compound 3: the middle estimate sits 16-fold (1.20 log units) above what was measured; measured number outside the range, below it.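

For the compounds shown here, at the place meta to a hydroxy group and para to a large group, the series now shows a first measured step in this assay: phenyl in place of pyridin-3-yl gives a 19-fold lower number from compound 1 to compound 3 (1.29 log units; beyond the scatter), and the earlier compounds offered no such measure for this position. The two groups have the same heavy-atom count and both are six-membered aromatic rings. Pyridin-3-yl has 1 hetero atom and 1 hydrogen-bond acceptor, whereas phenyl is a ring of carbon only with 0 hydrogen-bond acceptors. The read-out also has an upper end in this series, seen in compound 2, whose entry is a limit and not a number: the limit of > 10000 nM in this assay, at which 1 of the 3 values shown sits.

On these data alone, whether the step belongs to the ring nitrogen as such, or would also appear with other groups at this place, such as pyridin-4-yl, cyclohexyl or morpholine, remains open. Also open is how much of the number of compound 3 rests on the nitrile and the hydroxy group, as no compound shown changes either of them alone.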